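Cytotoxicity of a 4-methylphenyl ether analogue

A few compounds are considered here, and "the series" means these few. Any claim that something is new, unique, unknown or untested is made for them only; others in the source may bear on it.

Compound 1 `N#Cc1ccc(Nc2nc(Oc3ccccc3Cl)c3ccccc3n2)cc1` holds the lowest of the two measured numbers in an ADME assay on MT4 cells (Homo sapiens) for cytotoxicity, read by MTT assay, with a stated time of 4 days (on this read-out lower numbers stand for higher toxicity in this test and higher numbers for lower toxicity in this test), giving 38000 nM. Compound 3 `Cc1cc(C#N)cc(C)c1Oc1nc(Nc2ccc(C#N)cc2)nc2ccccc12` gives 203000 nM in this assay. For compound 2 `N#Cc1ccc(Nc2nc(Oc3ccc(F)cc3)c3ccccc3n2)cc1` this assay reports only a limit, > 351000 nM. Compound 4 `Cc1ccc(Oc2nc(Nc3ccc(C#N)cc3)nc3ccccc23)cc1` differs from compound 1 in a single place: 4-methylphenyl in place of 2-chlorophenyl on an oxygen on an aromatic ring. Two measured steps that start from compound 1 bear on this change: an at least 9.2-fold higher number from compound 1 to compound 2 (0.96 log units; beyond the scatter) and a 5.3-fold higher number from compound 1 to compound 3 (0.73 log units; beyond the scatter), both moving to higher numbers beyond the scatter. A step of comparable size in the same direction is therefore expected for compound 4, namely a 3.9-fold higher number from compound 1 to compound 4 (0.60 log units; beyond the scatter). Compound 4 is accordingly estimated at 150000 nM, within a range from 50000 nM to 400000 nM.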

Compound 4, half-maximal cytotoxic concentration: 87000 nM
Beside the measured number, compound 4's estimate is 1.7-fold (0.24 log units) above it; the range from low to high includes it.
By their numbers in this assay, from the lowest: compound 1; then compound 4; then compound 3. At a limit, above all of these: compound 2.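

In this assay, 4-methylphenyl also moves away from 2-chlorophenyl, with a 2.3-fold higher number from compound 1 to compound 4 (0.36 log units; beyond the scatter), so all three other groups on this oxygen give higher numbers than compound 1. Yet the groups are not equivalent: the methyl compound lies below the other two, with a 2.3-fold lower number from compound 3 to compound 4 (0.37 log units; beyond the scatter) and an at least 4.0-fold lower number from compound 2 to compound 4 (0.60 log units; beyond the scatter). That last step rests on a limit for compound 2: the limit of > 351000 nM in this assay, at which 1 of the 4 values shown sits.

From the compounds shown here alone, what a 4-chlorophenyl would give stays open, as does the effect of an amine or a carboxylic acid in place of the methyl. Going by these compounds, it is also open whether the low number of compound 1 follows from the chlorine itself or from its place on the ring.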